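From hexyl to isopropyl: a smaller group on nitrogen

The source may report more compounds than this note shows. Statements on the series, on what has been measured and on what is new or still open speak of the compounds shown alone.

Of the compounds shown here, three with a shared core have been measured in a functional assay on A549 cells (Homo sapiens) for antiproliferative activity, read by MTT assay, with a stated time of 48 h; on this read-out higher numbers stand for weaker inhibition of growth and lower numbers for stronger inhibition of growth. Compound 1 `CCCCCN(Cc1ccc(C(=O)NO)cc1)c1ncc(-c2ccc(C)cc2)s1`, with a pentyl chain, gives 9140 nM. Compound 2 `Cc1ccc(-c2cnc(N(CCCCOc3ccccc3)Cc3ccc(C(=O)NO)cc3)s2)cc1`, with a phenoxybutyl chain, gives 14200 nM. Compound 3 `CCCCCCN(Cc1ccc(C(=O)NO)cc1)c1ncc(-c2ccc(C)cc2)s1`, with a hexyl chain, gives 3710 nM, the lowest number of the three and beyond the scatter from both others.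

Compound 4 `Cc1ccc(-c2cnc(N(Cc3ccc(C(=O)NO)cc3)C(C)C)s2)cc1` changes compound 3 in one place: isopropyl in place of hexyl on a nitrogen on an aromatic ring. The nearest guide is the move from pentyl to hexyl, which gave a 2.5-fold lower number from compound 1 to compound 3 (0.39 log units; beyond the scatter), a modest change. Chain length alone does not explain the numbers, however. Compound 2 goes against a simple longer-is-better reading, since a 1.6-fold higher number from compound 1 to compound 2 (0.19 log units; within the scatter) stays within the scatter, while a 3.8-fold lower number from compound 2 to compound 3 (0.58 log units; beyond the scatter) is also modest. Within the data shown here, no measured compound carries a group as short as isopropyl, or a branched one, so this is an extrapolation. Losing the hexyl chain should therefore give up the advantage of compound 3 and perhaps a little more. The expected change is a 3.0-fold higher number from compound 3 to compound 4 (0.47 log units; beyond the scatter), a modest move towards weaker inhibition of growth. Compound 4 is estimated at 11000 nM, with an expected range of 5000 nM to 25000 nM.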

Compound 4, concentration for 50% growth inhibition: 3830 nM
Estimate against measurement, compound 4: 2.9-fold (0.46 log units) above, outside the stated range (below it).
By their numbers in this assay, from the lowest: compounds 3 and 4 (each within the scatter of the next); then compounds 1 and 2 (each within the scatter of the next).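

The change from hexyl to isopropyl on this nitrogen gives a 1.0-fold higher number from compound 3 to compound 4 (0.01 log units; within the scatter) in this assay, so a short branched group does as well here as the long straight chain. Compound 4 also stands apart from the two remaining compounds, with a 2.4-fold lower number from compound 1 to compound 4 (0.38 log units; beyond the scatter) and a 3.7-fold lower number from compound 2 to compound 4 (0.57 log units; beyond the scatter), so the numbers do not simply follow chain length: pentyl is longer than isopropyl and shorter than hexyl, yet the pentyl compound gives a higher number than either. No measurement at hand explains why these groups on the nitrogen compare as they do.

The compounds shown leave open whether a still smaller group on this nitrogen, such as methyl or ethyl, would keep the number of compound 3 and compound 4, and whether a ring such as cyclopropyl or cyclohexyl would do the same. They also leave open how a chain ending in an amine or a carboxylic acid would behave at this position, since the only chain here that carries anything at its end is the 4-phenoxybutyl group.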